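This account rests on a few compounds, and the source may have more. Where it says the series, first, only, none or still open, it means among the compounds named here.

Of the compounds shown here, two have been read so far in a physicochemical assay for lipophilicity, read by HPLC, at pH 7.5; on this read-out lower numbers stand for lower lipophilicity and higher numbers for higher lipophilicity. Compound 2 (`N#Cc1c(-c2ccc(Br)cc2)nc2cnccc2c1NCC(N)=O`) gives 1.9, the lower of the two numbers. Compound 1 (`CC[C@@H](Nc1c(C#N)c(-c2ccc(-c3ccccc3F)cc2)nc2cnccc12)C(N)=O`) gives 2.7, and the gap between the two lies beyond the scatter.

The next compound to be read is compound 3 (`CC[C@H](Nc1c(C#N)c(-c2ccc(Br)cc2)nc2cnccc12)C(N)=O`), which has no number yet. It departs from compound 2 by ethyl in place of hydrogen on a saturated chain carbon bound to a carbonyl carbon and a nitrogen on an aromatic ring, which turns carbamoylmethyl into 1-carbamoylpropyl.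

Among the compounds with values here, the series holds no measured pair differing in one place, so this step has no direct precedent and its size remains a judgement. Within the data shown here, the starting point is compound 2 at 1.9, and the only higher reading is compound 1 at 2.7. A moderate rise in this assay is expected, probably beyond the scatter, though a smaller one cannot be excluded. The estimated change is a number 0.50 log units higher from compound 2 to compound 3 (beyond the scatter). For compound 3 the expected value is 2.4, with an estimated range of 2 to 2.8.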

Compound 3, distribution coefficient: 2.3
Compound 3: middle estimate off by 0.10 log units, on the high side, and the stated range covers the measured number.
By their numbers in this assay, from the lowest: compound 2; then compound 3; then compound 1.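

In this assay, within the data shown here, ethyl in place of hydrogen on a saturated chain carbon bound to a carbonyl carbon and a nitrogen on an aromatic ring gives a number 0.40 log units higher from compound 2 to compound 3 (beyond the scatter) as the only single-place step so far. The earlier compounds shown here differed in more than one place and could not isolate this position, whereas this pair shows that the change from carbamoylmethyl to 1-carbamoylpropyl alone moves the read-out beyond the scatter. The step describes one change on one core, and no measurement is available to explain its size.

From the compounds shown here alone, a single step gives no trend with chain size at this carbon, so the readings for a methyl, a propyl or a longer chain, or for a cyclopropyl ring, remain open, as does the reading for a carbamoylmethyl analogue carrying a primary amine on the chain. Also open, going by these compounds, are whether the opposite configuration at this carbon gives a step of the same size and whether the ethyl step holds on the core of compound 1.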